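Swapping the core substituent of compound 1: an open question

The source may hold more compounds than are shown below. What is called first, only, known or untested is meant among the compounds shown, and "the series" means these compounds.

Compound 1 `COc1ccc(F)cc1CNCCCNc1ccnc2cc(Cc3ccc(C#N)cc3)ccc12` is one of three analogues that share a core and differ only in the aromatic group attached to a saturated chain carbon bound to an amine nitrogen. In a physicochemical assay for solubility, with a stated time of 18 h, at pH 7.4 (on this read-out lower numbers stand for lower solubility and higher numbers for higher solubility), compound 1 gives 4200 nM. Compound 2 `COc1cccc(CNCCCNc2ccnc3cc(Cc4ccc(C#N)cc4)ccc23)c1O` gives 4200 nM in this assay, and compound 3 `N#Cc1ccc(Cc2ccc3c(NCCCNCc4ccco4)ccnc3c2)cc1` gives 4200 nM; compound 1 therefore stands level with both, and the steps of no change at the digits printed from compound 1 to compound 2 (within the scatter), no change at the digits printed from compound 1 to compound 3 (within the scatter) and no change at the digits printed from compound 2 to compound 3 (within the scatter) all stay within the scatter.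

Compound 4 `COc1ccc(F)cc1CNCCCNc1ccnc2cc(Oc3cccc(N(C)C)c3)ccc12` departs from compound 1 at a different position: 3-(dimethylamino)phenoxy in place of 4-cyanobenzyl on an aromatic carbon. Within the data shown here, none of the measured steps touches this aromatic carbon of the core; each of them changes the group on the saturated chain carbon, and each left solubility unchanged. Among the measured compounds shown here, there is thus no measured step that bears directly on the change from compound 1 to compound 4, and the flatness of the three measured values is the only guide.

On that basis the step of a 1.1-fold higher number from compound 1 to compound 4 (0.03 log units; within the scatter) is expected to be small, with no direction favoured beyond the scatter. Compound 4 is estimated to give 4500 nM in this assay, with a range from 1800 nM to 12000 nM.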

Compound 4, solubility: 14500 nM
Compound 4: the middle estimate sits 3.2-fold (0.51 log units) below what was measured; the measured number lies above the stated range.
By their numbers in this assay, from the lowest: compounds 1, 2 and 3 (each within the scatter of the next); then compound 4.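

In this assay, the aromatic carbon of the shared core turns out to be a place where a change registers: the swap of 4-cyanobenzyl for 3-(dimethylamino)phenoxy gives a 3.5-fold higher number from compound 1 to compound 4 (0.54 log units; beyond the scatter), a modest step. The three groups on the saturated chain carbon had produced no step beyond the scatter, so the flat values of compounds 1, 2 and 3 describe that one site and do not hold for the core as a whole. No information is available on what lies behind this step.

The step exchanges the whole group at once, which leaves open what share belongs to the oxygen link and what to the dimethylamino group; a 3-(dimethylamino)benzyl or a 4-cyanophenoxy group on the same aromatic carbon would separate the two. Also open, on these data alone, is whether 3-(dimethylamino)phenoxy would give a step of similar size with furan-2-yl or 2-hydroxy-3-methoxyphenyl in place of 5-fluoro-2-methoxyphenyl on the saturated chain carbon.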